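Dechlorination of a benzyl amide and cytotoxicity

The source may report more compounds than this note shows. Statements on the series, on what has been measured and on what is new or still open speak of the compounds shown alone.

Compound 1 `CC(Sc1nnc(-c2ccncc2)s1)C(=O)Nc1ccccc1Cl` and compound 2 `CC(Sc1nnc(-c2ccncc2)s1)C(=O)Nc1ccccc1` share one core and differ only in that (hydrogen in place of chloro on an aromatic carbon). In an ADME assay on HepG2 cells (Homo sapiens) for cytotoxicity, with a stated time of 3 days (on this read-out lower numbers stand for higher toxicity in this test and higher numbers for lower toxicity in this test), compound 1 gives > 50000 nM, which is a limit of the assay rather than a number. Compound 2 gives > 50000 nM in this assay, again a limit. The step that the two limits leave unreadable from compound 1 to compound 2 therefore stays unreadable because of the limit of > 50000 nM in this assay, at which 2 of the 3 values shown sit.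

Compound 3 `CC(Sc1nnc(-c2ccncc2)s1)C(=O)NCc1ccc(Cl)cc1` differs from compound 1 in that (4-chlorobenzyl in place of 2-chlorophenyl on an amide-type nitrogen). For compound 3 the result in this assay is "not determined" (no result reported), so no number is available for it.

Compound 4 `CC(Sc1nnc(-c2ccncc2)s1)C(=O)NCc1ccccc1` is not yet measured. It differs from compound 3 in that (hydrogen in place of chloro on an aromatic carbon). Within the data shown here, this is the same kind of change as the one from compound 1 to compound 2, but the place is not the same: in compound 3 the chloro sits para to a large group, in compound 1 ortho to a large group.

In this assay compound 4 is expected to give 60000 nM, with a likely span from 25000 nM to 200000 nM, and most probably only a limit will be reported; this expectation rests on (the limit of > 50000 nM in this assay, at which 2 of the 3 values shown sit).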

Compound 4, half-maximal cytotoxic concentration: > 50000 nM
Compound 4 ended at the assay's limit (the forecaster's own chance of this, stated with the estimate: 75%); the middle value does not contradict the limit.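

In this assay compound 4 gives > 50000 nM, which is a limit. No new step can be read from compound 1 or compound 2 to compound 4, because all three compounds sit at that limit: the limit of > 50000 nM in this assay, at which 3 of the 4 values shown sit.

The compounds shown leave open how far any of these amides lies from the limit, and where compound 3 stands against compound 4.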